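The source may report more compounds than this note shows. Statements on the series, on what has been measured and on what is new or still open speak of the compounds shown alone.

In a functional assay on MCF-10A cells (Homo sapiens) for antiproliferative activity, with a stated time of 48 h (on this read-out higher numbers stand for an effect only at larger amounts of compound and lower numbers for an effect already at smaller amounts), compound 1 `COc1ccc2nc(C)cc(NCc3ccccc3F)c2c1` gives 14000 nM, compound 2 `COc1ccc2nc(C)cc(NCc3ccc(F)cc3F)c2c1` gives 11600 nM and compound 3 `COc1ccc2nc(C)cc(NCc3ccc(F)c(C(F)(F)F)c3)c2c1` gives 11300 nM. Compound 2 lies within the scatter of both other compounds, so the numbers show no separation around it. For the measured compounds named here, compound 4 `COc1ccc2nc(C)cc(NCc3ccc(F)cc3C(F)(F)F)c2c1` has no measurement yet. It differs from compound 2 by trifluoromethyl in place of fluoro on an aromatic carbon, ortho to a large group. Going by the values given here, the one measured step that changes a single place is a 1.2-fold lower number from compound 1 to compound 2 (0.08 log units; within the scatter), fluoro in place of hydrogen on an aromatic carbon, and it stays within the scatter. Compound 3, at 11300 nM, also carries a trifluoromethyl group elsewhere on the ring, and its value sits close to that of compound 2. Among the compounds with values here, no measured step exchanges these two groups, so this support is indirect. No change beyond the scatter is expected in this assay. The estimated step is a 1.1-fold lower number from compound 2 to compound 4 (0.02 log units; within the scatter). Compound 4 is expected at 11000 nM, with an estimated range of 5500 nM to 22000 nM.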

Compound 4, half-maximal effective concentration: 5200 nM
Compound 4: the middle estimate sits 2.1-fold (0.33 log units) above what was measured; measured number outside the range, below it.
By their numbers in this assay, from the lowest: compound 4; then compounds 3, 2 and 1 (each within the scatter of the next).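

In this assay, for the compounds shown here, the group on the aromatic carbon ortho to a large group makes a difference: trifluoromethyl in place of fluoro gives a 2.2-fold lower number from compound 2 to compound 4 (0.35 log units; beyond the scatter), a modest step but the first single-place change to lie beyond the scatter. Going by these compounds alone, the only earlier single-place step, a 1.2-fold lower number from compound 1 to compound 2 (0.08 log units; within the scatter), changed a different ring carbon and stayed within the scatter, so it gave no information about this position. The finding rests on one pair of compounds, and nothing measured here accounts for the step.

The compounds shown leave open how this position responds to other groups, such as chloro, methyl, methoxy or an amine, and so whether the step follows group size or something else. On these data alone, it also remains open whether the step persists without the fluoro group that sits meta to this position.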